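Ethyl in place of the benzamide on the shared core

The source may hold more compounds than are shown below. What is called first, only, known or untested is meant among the compounds shown, and "the series" means these compounds.

Measured compounds in an assay on isolated protein for binding affinity to adenosine receptor A1 (Bos taurus); on this read-out lower numbers stand for stronger inhibition and higher numbers for weaker inhibition:
- compound 1, `Clc1ccccc1Cn1nnc2c(NC3CCC3)nc(-c3ccccc3)nc21`: 24000000 nM
- compound 2, `COc1ccc(C(=O)Nc2nc(-c3ccccc3)nc3c2nnn3Cc2ccccc2F)cc1`: 21900000 nM
- compound 3, `CCCNc1nc(-c2ccccc2)nc2c1nnn2Cc1ccccc1`: 37000000 nM

The three compounds share one core and differ only in the group on the ring nitrogen and in the substituent on the benzyl group. In this assay compound 1 gives 24000000 nM, compound 2 gives 21900000 nM and compound 3 gives 37000000 nM. Compound 2 gives the smallest of the three numbers, but its gaps to compound 1 and to compound 3 both fall within the usual scatter, so no order can be read among them.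

Compound 4, `CCNc1nc(-c2ccccc2)nc2c1nnn2Cc1ccccc1F`, has not been measured in this assay. It differs from compound 2 in one place: ethyl in place of (4-methoxyphenyl)carbonyl on a nitrogen on an aromatic ring. Compound 3 already carries a short alkyl chain on the same nitrogen and gives 37000000 nM, a number within the scatter of compound 2, so the change to an ethylamino group gives no grounds to expect a step beyond the scatter in either direction. Compound 4 is therefore expected to give 30000000 nM in this assay, with a range from 8000000 nM to 120000000 nM. The expected step from compound 2 to compound 4 is a 1.4-fold higher number from compound 2 to compound 4 (0.14 log units; within the scatter), a difference that is estimated to stay within the scatter.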

Compound 4, inhibition constant: 11000000 nM
For compound 4 the middle estimate is 2.7-fold (0.44 log units) above the measured one; measured number inside the range.
By their numbers in this assay, from the lowest: compounds 4, 2, 1 and 3 (each within the scatter of the next, the first and the last beyond it).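

In this assay, for the compounds shown here, the exchange of (4-methoxyphenyl)carbonyl for ethyl on a nitrogen on an aromatic ring gives a 2.0-fold lower number from compound 2 to compound 4 (0.30 log units; within the scatter) and is the first comparison here that changes this nitrogen alone, since compounds 1, 2 and 3 each differ from one another in more than one place. It shows that a group of 10 heavy atoms, with a six-membered aromatic ring, a carbonyl and 2 hydrogen-bond acceptors, can give way to one of 2 heavy atoms with no ring and no acceptors while the number stays within the scatter, so this single pair shows no measurable dependence on the larger group. No measurement presented here accounts for this outcome.

Still open, going by these compounds, is whether a free amine, a plain acetyl group or a longer chain such as hexyl on this nitrogen would also stay within the scatter of compound 2, or whether one of them would move the number beyond it. Also open, on these data alone, is whether the same exchange would give a similar step with chlorine in place of fluorine on the benzyl group.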